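Swapping a Propyl Chain for a Tert-Butoxy Group

A few compounds are considered here, and "the series" means these few. Any claim that something is new, unique, unknown or untested is made for them only; others in the source may bear on it.

Compound 1 `CCCC(=O)N1CCC(N2CCN(C(=O)c3c(NC(=O)NCC)sc4ccccc34)CC2)CC1` has no result in a functional assay on HepG2 cells (Homo sapiens) for inhibition, read by scintillation counting, with a stated time of 2 h; on this read-out higher numbers stand for weaker inhibition and lower numbers for stronger inhibition: compound 1 gives "not determined" (no result reported). Compound 2 `CCNC(=O)Nc1sc2ccccc2c1C(=O)N1CCN(C2CCN(C(=O)CC(C)C)CC2)CC1` is in the same position, since compound 2 gives "not determined" (no result reported) in this assay. Going by the values given here, the only number comes from compound 3 `CCNC(=O)Nc1sc2ccccc2c1C(=O)N1CCN(C2CCN(C(=O)C3CCCCC3)CC2)CC1`, where compound 3 gives 146 nM in this assay. Compound 4 `CCNC(=O)Nc1sc2ccccc2c1C(=O)N1CCN(C2CCN(C(=O)OC(C)(C)C)CC2)CC1` is still to be tested. It differs from compound 1 by tert-butoxy in place of propyl on a carbonyl carbon. Among the compounds with values here, with no measured step for compound 1, the direction of this change cannot be read from the data; the nearest anchor is compound 3, and a change of similar size there suggests no shift beyond the usual scatter. Compound 4 is therefore expected to reach about 150 nM, within a range from 40 nM to 600 nM.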

Compound 4, half-maximal inhibitory concentration: 79 nM
Estimate against measurement, compound 4: 1.9-fold (0.28 log units) above, within the range that was stated.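

Going by these compounds alone, the first step that can be read at this carbonyl carbon in this assay is a 1.8-fold lower number from compound 3 to compound 4 (0.27 log units; within the scatter) and stays within the usual scatter. Tert-butoxy and cyclohexyl therefore cannot be told apart here, so the ring of cyclohexyl is not needed for a value in this range. No measured evidence explains this result.

The steps from compound 1 and compound 2 cannot be read, as neither compound has a number. Going by these compounds, whether an amine or a carboxylic acid on this carbonyl carbon would shift the value beyond the scatter remains open.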